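The source may report more compounds than this note shows. Statements on the series, on what has been measured and on what is new or still open speak of the compounds shown alone.

Compound 1 `CC(C)(C)CCN1C(=O)C(C2=NS(=O)(=O)c3cc(NS(C)(=O)=O)ccc3N2)=C(O)C2CCCCC21`: > 33000 nM in an ADME assay on Huh-7 cells (Homo sapiens) for cytotoxicity, with a stated time of 72 h; on this read-out lower numbers stand for higher toxicity in this test and higher numbers for lower toxicity in this test
Compound 2 `CS(=O)(=O)Nc1ccc2c(c1)S(=O)(=O)N=C(C1=C(O)C3CCCC3N(C3CCCCC3)C1=O)N2`: > 10000 nM
Compound 3 `CS(=O)(=O)Nc1ccc2c(c1)S(=O)(=O)N=C(C1=C(O)[C@H]3CCC[C@H]3N(CC3CC3)C1=O)N2`: > 33000 nM

The three compounds share one core, and in this assay none of them yields a number. Compound 1 reaches only a limit, > 33000 nM. Compound 2 reaches only a limit, > 10000 nM. Compound 3 likewise reaches only a limit, > 33000 nM. Two of the three values sit at the limit of > 33000 nM in this assay, at which 2 of the 3 values shown sit, and one at the limit of > 10000 nM in this assay, at which 1 of the 3 values shown sits; compound 2 is the one at the lower bound, so its standing is known only as a bound, and nothing in these numbers separates it from compound 1 or compound 3.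

Compound 4 `CS(=O)(=O)Nc1ccc2c(c1)S(=O)(=O)N=C(C1=C(O)C3CCCC3N(Cc3ccccn3)C1=O)N2` differs from compound 2 by (pyridin-2-yl)methyl in place of cyclohexyl on an amide-type nitrogen in a ring. Going by the values given here, no measured pair isolates this change, so the expectation rests on the three limits alone. In this assay the expected step is a step that the limit leaves unreadable from compound 2 to compound 4, none beyond the scatter. Compound 4 is thus expected at 30000 nM, within 10000 nM to 100000 nM, most probably again reported as a limit rather than a number.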

Compound 4, half-maximal cytotoxic concentration: > 33000 nM
Compound 4 was reported as a limit (the forecaster's own chance of this, stated with the estimate: 85%); middle value at least 1.1-fold (0.04 log units) away from the limit.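

No step can be read from compound 2 to compound 4, since both stand only as limits in this assay. The compounds shown leave open at what concentration any of them turns cytotoxic, and whether (pyridin-2-yl)methyl in place of cyclohexyl alters that concentration.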